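The source may hold more compounds than are shown below. What is called first, only, known or untested is meant among the compounds shown, and "the series" means these compounds.

Of the compounds shown here, two from this series have been measured in a functional assay on MCF7 cells (Homo sapiens) for antiproliferative activity, read by sulforhodamine B assay, with a stated time of 48 h; a higher number here means a weaker inhibitor, a lower number a stronger inhibitor. Compound 1 `COc1ccc(/C=C/C(=O)c2ccccc2-c2ccc(F)cc2)cc1O` gives 7 nM, and compound 2 `COc1ccc(/C=C/C(=O)c2ccccc2-c2cccc(F)c2)cc1` gives 84 nM. Compound 2 therefore holds the higher of the two numbers and is the weaker inhibitor, with a gap to compound 1 that lies beyond the scatter. Within the data shown here, the two differ in more than one place, so this gap cannot be assigned to any single change, and no measured pair isolates the hydroxy on its own.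

Compound 3 `COc1ccc(/C=C/C(=O)c2ccccc2-c2cccc(F)c2)cc1O` is compound 2 with hydroxy in place of hydrogen on an aromatic carbon, ortho to a methoxy group and meta to a large group: hydroxy in place of hydrogen on an aromatic carbon. Compound 3 shares this hydroxy with compound 1, which reaches 7 nM, although the fluorine sits elsewhere in compound 1. A clear move towards stronger inhibition in this assay is therefore expected, beyond the scatter, but this rests on a single comparison. The expected step is a 7.0-fold lower number from compound 2 to compound 3 (0.85 log units; beyond the scatter). For compound 3 the estimated value is 12 nM, with an expected range of 4 nM to 40 nM.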

Compound 3, half-maximal inhibitory concentration: 2 nM
Estimate against measurement, compound 3: 6.0-fold (0.78 log units) above; the measured number lies below the stated range.
By their numbers in this assay, from the lowest: compound 3; then compound 1; then compound 2.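

In this assay, among these compounds, hydroxy in place of hydrogen on an aromatic carbon, ortho to a methoxy group and meta to a large group, gives a 42-fold lower number from compound 2 to compound 3 (1.62 log units; beyond the scatter), and this is the first pair to isolate the hydroxy, showing that this single change at this position carries a large gain on its own. With the hydroxy kept in place, 3-fluorophenyl in place of 4-fluorophenyl on an aromatic carbon gives a 3.5-fold lower number from compound 1 to compound 3 (0.54 log units; beyond the scatter), a modest step that nonetheless lies beyond the scatter, so the place of the fluorine also counts, and the earlier gap between compound 1 and compound 2 can now be read as including a hydroxy gain partly offset by this fluorine change. Nothing in the data at hand accounts for the size of either step.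

Going by these compounds, the hydroxy step rests on one pair, so it remains open whether it would be of similar size on the 4-fluorophenyl series of compound 1. On these data alone, it is equally open whether the gain is specific to hydroxy or would also appear with an amine or a carboxylic acid at the same position on the ring.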